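Chloro on Two Cores and the Minimum Effective Dose

The source may report more compounds than this note shows. Statements on the series, on what has been measured and on what is new or still open speak of the compounds shown alone.

Compound 1 `CC(C)(C)/N=C(\NC#N)Nc1cccnc1Cl`: in a functional assay on the whole organism (blood, strain Wistar-Okamoto) with Rattus norvegicus as the target, with a stated time of 5 days (on this read-out higher numbers stand for an effect only at larger amounts of compound and lower numbers for an effect already at smaller amounts), compound 1 gives 5 mg/kg.
Compound 2 `CC(C)(C)/N=C(\NC#N)Nc1ccc(Cl)nc1Cl`: in this assay compound 2 gives > 50 mg/kg, which is a limit of the assay and not a number.
Compound 3 `CC(C)(C)/N=C(\NC#N)Nc1ccccn1`: in this assay compound 3 gives > 20 mg/kg, again a limit of the assay and not a number.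

Compound 2 arises from compound 1 by chloro in place of hydrogen on an aromatic carbon. This step gave an at least 10-fold higher number from compound 1 to compound 2 (1.00 log units; beyond the scatter); compound 2 sits at the limit of > 50 mg/kg in this assay, at which 1 of the 3 values shown sits, so the step can only be bounded. Compound 3 sits at the limit of > 20 mg/kg in this assay, at which 1 of the 3 values shown sits. How the core of compound 3 differs from that of compound 1 is not broken down here.

Compound 4 `CC(C)(C)/N=C(\NC#N)Nc1ccc(Cl)cn1` has not yet been measured. It arises from compound 3 by chloro in place of hydrogen on an aromatic carbon. For the measured compounds named here, this is the same kind of change as the one from compound 1 to compound 2, but the place is not identical: there the entering chloro sat next to the ring nitrogen and meta to a chloro group, whereas in compound 4 it sits two atoms from the ring nitrogen.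

Going by the values given here, for compound 4 in this assay a step that the limit leaves unreadable from compound 3 to compound 4 is expected, because compound 3 already gives > 20 mg/kg as a limit and the only measured instance of this kind of change gave an at least 10-fold higher number from compound 1 to compound 2 (1.00 log units; beyond the scatter). Compound 4 is therefore estimated at 60 mg/kg, with a range from 20 mg/kg to 200 mg/kg, and most likely only a limit will be reported.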

Compound 4, minimum effective dose: 25 mg/kg
Estimate against measurement, compound 4: 2.4-fold (0.38 log units) above, and the stated range covers the measured number.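

No size can be read for the step from compound 3 to compound 4, because compound 3 stands only at a limit of the assay and not at a number: the limit of > 20 mg/kg in this assay, at which 1 of the 4 values shown sits.

The compounds shown leave open how far chloro in place of hydrogen on an aromatic carbon shifts the minimum effective dose on the core of compound 3, and whether that shift runs the same way as on the core of compound 1.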